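The compounds below may be only part of what the source reports. "The series", "measured", "known", "first", "only" and "open" are said of these compounds alone.

Two measured compounds frame this step. Compound 1 `O=C(Nc1ccc(OC(F)F)cc1)c1cccc(/C=C2\CC(=O)N(c3ccccc3)C2=O)c1` carries a 4-(difluoromethoxy)phenyl group on the amide-type nitrogen, and in an ADME assay on NCM460 cells (Homo sapiens) for cytotoxicity, read by MTT assay, with a stated time of 72 h (a lower number here means a stronger inhibitor, a higher number a weaker inhibitor), compound 1 gives > 100000 nM, which is a limit of the assay rather than a number. Compound 2 `O=C(Nc1cccc(F)c1)c1cccc(/C=C2\CC(=O)N(c3ccccc3)C2=O)c1` has a 3-fluorophenyl group in that place, and in this assay compound 2 gives > 100000 nM, again a limit rather than a number. The change from compound 1 to compound 2 yields a step that the two limits leave unreadable from compound 1 to compound 2, so the size of that step cannot be read. What the two results have in common is the limit of > 100000 nM in this assay, at which 2 of the 2 values shown sit.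

Compound 3 `CSc1cccc(NC(=O)c2cccc(/C=C3\CC(=O)N(c4ccccc4)C3=O)c2)c1` is not yet measured. It differs from compound 2 by methylsulfanyl in place of fluoro on an aromatic carbon. For the measured compounds named here, the one measured step in this assay sets no readable size and no direction, so nothing in the data points to a step beyond the scatter for this change either. The step from compound 2 to compound 3 is therefore expected to be a step that the limit leaves unreadable from compound 2 to compound 3. Compound 3 is estimated to give 150000 nM in this assay, within a range from 50000 nM to 500000 nM, most likely again as a limit.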

Compound 3, half-maximal inhibitory concentration: > 100000 nM
Compound 3 gave a limit, no number (the forecaster's own chance of this, stated with the estimate: 85%); the middle value lies beyond the limit too.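

In this assay compound 3 gives > 100000 nM, a limit of the assay and not a number. The steps linking compound 3 to compound 1 and compound 2 therefore cannot be read, and the three results share only this: the limit of > 100000 nM in this assay, at which 3 of the 3 values shown sit. The compounds shown leave open how large any difference among these three compounds is, and in which direction it runs.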